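The source may report more compounds than this note shows. Statements on the series, on what has been measured and on what is new or still open speak of the compounds shown alone.

In a physicochemical assay for solubility, using the shake flask method, in simulated intestinal fluid, measured as kinetic solubility, with a stated time of 2 h, at 25 degrees C, at pH 6.5 (a lower number here means a less soluble compound, a higher number a more soluble compound), compound 3 `Cc1noc(-c2nc(C)c3c(c2N)C(=O)N(Cc2ccc(OC(F)F)cc2)C3=O)n1` gives < 5000 nM as a limit of the assay and not a number. Compound 1 `Cc1noc(-c2nc(C)c3c(c2N)C(=O)N(Cc2ccc(Cl)cc2)C3=O)n1` gives < 5000 nM as a limit too. Compound 2 `COc1ccc(CN2C(=O)c3c(C)nc(-c4nc(C)no4)c(N)c3C2=O)cc1` gives < 5000 nM as a limit too. This leaves the limit of < 5000 nM in this assay, at which 3 of the 3 values shown sit, as the whole picture so far. Compound 4 `Cc1noc(-c2nc(C)c3c(c2N)C(=O)N(Cc2ccc(CO)cc2)C3=O)n1` has hydroxymethyl in place of difluoromethoxy on an aromatic carbon, para to a large group (hydroxymethyl in place of difluoromethoxy on an aromatic carbon). Three measured steps change this same group, namely a step that the two limits leave unreadable from compound 1 to compound 2 and a step that the two limits leave unreadable from compound 1 to compound 3 and a step that the two limits leave unreadable from compound 2 to compound 3 and none of them has a readable size. They therefore give no direction. In this assay the step expected is a step that the limit leaves unreadable from compound 3 to compound 4 and none beyond the scatter is foreseen. For compound 4 the expected value is 4000 nM with a range from 1500 nM to 10000 nM in this estimate.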

Compound 4, solubility: < 5000 nM
Compound 4: no number, only a limit; the forecaster's own chance of this, stated with the estimate: 70%; the middle value does not contradict the limit.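

None of the steps among compound 1, compound 2, compound 3 and compound 4 can be read, because all four stop at one limit: the limit of < 5000 nM in this assay, at which 4 of the 4 values shown sit.

The actual values of these compounds in this assay, and so the size of any difference between them, remain open.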